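A Chlorine for a Methyl on the Phenoxy Ring

The compounds below may be only part of what the source reports. "The series", "measured", "known", "first", "only" and "open" are said of these compounds alone.

The three measured compounds share one core and differ in the carbamoylphenyl group and in the phenoxy ring. Within the data shown here, in a functional assay on MIA PaCa-2 cells (Homo sapiens) for antiproliferative activity, read by MTT assay, with a stated time of 72 h (on this read-out higher numbers stand for an effect only at larger amounts of compound and lower numbers for an effect already at smaller amounts), compound 1 `Cc1nn(Cc2cccc(C(N)=O)c2)c(C)c1NC(=O)c1ccc(COc2ccccc2)cc1` gives 9200 nM, and compound 2 `Cc1nn(Cc2ccccc2C(N)=O)c(C)c1NC(=O)c1ccc(COc2ccccc2)cc1` gives 42000 nM; the move a 4.6-fold higher number from compound 1 to compound 2 (0.66 log units; beyond the scatter) is the only single-point step measured so far. Compound 3 `CNC(=O)c1cccc(Cn2nc(C)c(NC(=O)c3ccc(COc4cccc(C)c4)cc3)c2C)c1` gives 6200 nM, the lowest of the three numbers, though compound 1 sits within the scatter of it and only compound 2 lies beyond it.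

Compound 4 `CNC(=O)c1cccc(Cn2nc(C)c(NC(=O)c3ccc(COc4ccc(Cl)cc4)cc3)c2C)c1` differs from compound 3 by 4-chlorophenyl in place of 3-methylphenyl on an oxygen on a saturated carbon. Among the measured compounds shown here, no measured step touches this place: the one measured step concerns the carbamoylphenyl group and says nothing about the phenoxy ring. The step of a 1.0-fold higher number from compound 3 to compound 4 (0.02 log units; within the scatter) is expected to remain within the scatter. Compound 4 is therefore estimated at 6500 nM in this assay, with a range from 2500 nM to 17000 nM.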

Compound 4, half-maximal effective concentration: 4200 nM
For compound 4 the middle estimate is 1.5-fold (0.19 log units) above the measured one, and the stated range covers the measured number.
By their numbers in this assay, from the lowest: compounds 4, 3 and 1 (each within the scatter of the next, the first and the last beyond it); then compound 2.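

Among these compounds, the phenoxy ring is a place where no step had been read before, and here the exchange of 3-methylphenyl for 4-chlorophenyl on an oxygen on a saturated carbon gives a 1.5-fold lower number from compound 3 to compound 4 (0.17 log units; within the scatter) in this assay. Among the compounds shown here, the change therefore stays within the scatter, unlike the only earlier step, a 4.6-fold higher number from compound 1 to compound 2 (0.66 log units; beyond the scatter), which concerned the carbamoylphenyl group and lay beyond it. No measurement is available that could explain this result.

This single step changes the substituent and its ring position together, so the contribution of each stays unresolved without 3-chlorophenyl or 4-methylphenyl for comparison. The compounds shown also leave open how this series responds to a phenoxy ring carrying a methoxy group, an amine or a carboxylic acid.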